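The source may report more compounds than this note shows. Statements on the series, on what has been measured and on what is new or still open speak of the compounds shown alone.

Of the compounds shown here, two have been measured in an in vitro assay on LLC-PK1 cells for displacement of a labelled ligand from growth hormone secretagogue receptor type 1 (Homo sapiens); on this read-out lower numbers stand for stronger inhibition and higher numbers for weaker inhibition. Compound 1, `O=C(N[C@H](c1c[nH]c2ccccc12)c1nnc(CCc2ccccc2)n1-c1ccccc1)c1ccccn1`, gives 105 nM in this assay. Compound 2, `COc1ccc(-n2c(CCc3ccccc3)nnc2[C@H](NC(=O)Cc2ccccn2)c2c[nH]c3ccccc23)c(OC)c1`, gives 120 nM in this assay; of the two numbers it is the one that lies nearer the upper end, but the gap to compound 1 falls within the usual scatter of repeated measurements, so the two values cannot be told apart. Compound 3, `O=C(Cc1ccccn1)N[C@H](c1c[nH]c2ccccc12)c1nnc(CCc2ccccc2)n1-c1ccccc1`, has not yet been measured. It differs from compound 2 at one place: phenyl in place of 2,4-dimethoxyphenyl on an aromatic nitrogen. Going by the values given here, no measured pair in this set shares that change, so nothing shows what it does on its own. Given that compound 2 gives 120 nM, compound 3 is expected to stay close to it, and the step of a 1.1-fold lower number from compound 2 to compound 3 (0.04 log units; within the scatter) is estimated to be none beyond the scatter. Compound 3 is therefore estimated at 110 nM, with a likely range from 50 nM to 250 nM.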

Compound 3, half-maximal inhibitory concentration: 700 nM
Compound 3: middle estimate off by 6.4-fold (0.80 log units), on the low side; measured number above the stated range.
By their numbers in this assay, from the lowest: compounds 1 and 2 (each within the scatter of the next); then compound 3.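

In this assay, phenyl in place of 2,4-dimethoxyphenyl on the aromatic nitrogen gives a 5.8-fold higher number from compound 2 to compound 3 (0.77 log units; beyond the scatter) while the carbonyl carbon carries (pyridin-2-yl)methyl, so the group at this position does affect the read-out in that setting. With phenyl on that nitrogen, (pyridin-2-yl)methyl in place of pyridin-2-yl on the carbonyl carbon gives a 6.7-fold higher number from compound 1 to compound 3 (0.82 log units; beyond the scatter), so compound 3 stands apart through either single change. Nothing available here accounts for either step. The compounds shown leave open whether the step at the aromatic nitrogen would keep its size with pyridin-2-yl on the carbonyl carbon. They also leave open whether one methoxy group alone would match 2,4-dimethoxyphenyl, and what a longer chain such as 2-(pyridin-2-yl)ethyl on the carbonyl carbon would do.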